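Aryl-iminosugar series: removing the phenolic hydroxy

This account rests on a few compounds, and the source may have more. Where it says the series, first, only, none or still open, it means among the compounds named here.

Measured so far in an assay on isolated protein for inhibition of alpha-galactosidase (Coffea arabica), tested at 1000 uM; a higher number here means more inhibition at the concentration tested (going by the name of the read-out), a lower number less inhibition:
compound 1 `OC[C@@]1(c2ccc(O)cc2)NC[C@@H](O)[C@@H]1O` — 1.2%
compound 2 `OC[C@]1(c2ccc(O)cc2)NC[C@H](O)[C@H]1O` — 3.6%

Within the data shown here, compound 1 gives the lowest of the two numbers; its only neighbour is compound 2, which differs solely in the configuration as drawn, the step being a number 2.4 percentage points higher from compound 1 to compound 2 (within the scatter). Compound 3 `OC[C@@]1(c2ccccc2)NC[C@@H](O)[C@@H]1O` carries the change (hydrogen in place of hydroxy on an aromatic carbon). Among the measured compounds shown here, no measured step bears on this change, since the fact that compounds 1 and 2 differ only in the configuration as drawn covers configuration only; both measured numbers sit near the bottom of the read-out, so no movement beyond the scatter is expected. For compound 3 the estimated value is 3% (range 0% to 12%), the expected step being a number 1.8 percentage points higher from compound 1 to compound 3 (within the scatter).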

Compound 3, a percentage reported as inhibition, at one concentration (the size of the read-out at that concentration, not a potency): 9.9%
Compound 3: the middle estimate sits 6.9 percentage points below what was measured; the range from low to high includes it.
By their numbers in this assay, from the lowest: compounds 1, 2 and 3 (each within the scatter of the next).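

In this assay, the hydroxy on the aromatic carbon is now probed directly: with hydrogen in its place, the step is a number 8.7 percentage points higher from compound 1 to compound 3 (within the scatter). On the core of compound 1, this position therefore shows no effect of the hydroxy that can be told from the scatter. No available information bears on this change.

From the compounds shown here alone, whether a methoxy group, a fluorine atom or an amine on that carbon would move the number beyond the scatter stays open. So does the same exchange on compound 2, the mirror image of compound 1.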